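This account rests on a few compounds, and the source may have more. Where it says the series, first, only, none or still open, it means among the compounds named here.

Of the compounds shown here, two that share one core have so far been measured in an ADME assay on the whole organism (strain FVB) for pharmacokinetics, with Mus musculus as the target, read by LC-MS, at a dose of 30 mg/kg by the oral route; a lower number here means less compound in the circulation, a higher number more compound in the circulation at the dose given. Compound 1 `NCCOc1ccc([C@H]2CC[C@]3(CC2)OOC2(O3)C3CC4CC(C3)CC2C4)cc1` gives 1370 ng.h/mL. Within the data shown here, compound 2 `O[C@H]1CC[C@H](NCCCOc2ccc([C@H]3CC[C@]4(CC3)OOC3(O4)C4CC5CC(C4)CC3C5)cc2)CC1` gives 6570 ng.h/mL, which is the highest of the two numbers in hand, and the single measured step between them reads a 4.8-fold higher number from compound 1 to compound 2 (0.68 log units; beyond the scatter). Compound 3 `c1cc([C@H]2CC[C@]3(CC2)OOC2(O3)C3CC4CC(C3)CC2C4)ccc1OCCOC1CCNCC1` has not yet been measured. It differs from compound 2 in one place: (piperidin-4-yl)oxy in place of ((4-hydroxycyclohexyl)amino)methyl on a saturated chain carbon, two bonds along the chain from an oxygen on an aromatic ring. Among the measured compounds shown here, the only measured step that bears on this change is the one from compound 1 to compound 2, where building out the chain end into a larger group with a second ring raised the number by a modest amount, beyond the scatter. The change to compound 3 moves partly back in the other direction, since the entering group is the smaller of the two, but it still keeps a ring and a nitrogen at the chain end. With just that one step to go on, the expectation for compound 3 is a small fall from compound 2, estimated as a 1.9-fold lower number from compound 2 to compound 3 (0.27 log units; within the scatter). Compound 3 is therefore expected to give about 3500 ng.h/mL, within a range from 1200 ng.h/mL to 10000 ng.h/mL.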

Compound 3, area under the concentration-time curve: 9180 ng.h/mL
For compound 3 the middle estimate is 2.6-fold (0.42 log units) below the measured one; the measured number falls inside the stated range.
By their numbers in this assay, from the lowest: compound 1; then compounds 2 and 3 (each within the scatter of the next).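

In this assay, putting (piperidin-4-yl)oxy in place of ((4-hydroxycyclohexyl)amino)methyl on a saturated chain carbon, two bonds along the chain from an oxygen on an aromatic ring, gives a 1.4-fold higher number from compound 2 to compound 3 (0.15 log units; within the scatter), so the two groups cannot be told apart here, although the entering group is the smaller by heavy atoms, carries its nitrogen in the ring and has no defined stereocentres. Measured against the plain amino group, the same entering group gives a 6.7-fold higher number from compound 1 to compound 3 (0.83 log units; beyond the scatter), which sits beside a 4.8-fold higher number from compound 1 to compound 2 (0.68 log units; beyond the scatter) and shows that among these three compounds the step up from amino is not tied to one particular ring-bearing group. Nothing available explains these numbers.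

A dimethylamino group at this place would show whether a ring at the chain end matters at all, since both higher compounds carry one. A cyclohexyloxy group would likewise show whether the nitrogen in the ring of compound 3 is needed.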